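Swapping fluoro for chloro beside the hydroxy group

The source may hold more compounds than are shown below. What is called first, only, known or untested is meant among the compounds shown, and "the series" means these compounds.

Of the compounds shown here, three built on one shared core have been tested in a functional assay on LOX IMVI cells (Homo sapiens) for cytotoxicity, read by MTT assay, with a stated time of 24 h; a higher number here means a weaker inhibitor, a lower number a stronger inhibitor. Compound 3 `O=S(=O)(NCCCNc1nccc(-c2[nH]c(-c3ccccc3)nc2-c2ccc(F)c(O)c2)n1)c1cccc2ccccc12` gives 3710 nM, the lowest of the three numbers. Compound 1 `O=S(=O)(NCCCNc1nccc(-c2[nH]c(-c3ccccc3)nc2-c2ccc(F)c(O)c2)n1)c1ccc(Br)cc1` gives 5660 nM, and the step of a 1.5-fold lower number from compound 1 to compound 3 (0.18 log units; within the scatter) stays within the scatter, so these two cannot be ranked against each other. Compound 2 `Cc1ccc(S(=O)(=O)NCCCNc2nccc(-c3[nH]c(-c4ccccc4)nc3-c3ccc(F)c(O)c3)n2)cc1` gives 26300 nM; the step of a 7.1-fold lower number from compound 2 to compound 3 (0.85 log units; beyond the scatter) lies beyond the scatter, as does a 4.6-fold higher number from compound 1 to compound 2 (0.67 log units; beyond the scatter). All three measured steps change only the group on the sulfonyl sulfur, at the far end of the molecule.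

Compound 4 `O=S(=O)(NCCCNc1nccc(-c2[nH]c(-c3ccccc3)nc2-c2ccc(Cl)c(O)c2)n1)c1cccc2ccccc12` differs from compound 3 in a single place: chloro in place of fluoro on an aromatic carbon. Read one bond further out, the 4-fluoro-3-hydroxyphenyl group becomes 4-chloro-3-hydroxyphenyl. Among the measured compounds shown here, no measured step touches this part of the core, so there is no direct precedent for the change, and a swap of one halogen for one other on an aromatic carbon is expected to give a step no larger than the scatter, in either direction. The estimated step is a 1.1-fold lower number from compound 3 to compound 4 (0.03 log units; within the scatter), expected to remain within the scatter. The estimate for compound 4 in this assay is 3500 nM, with a range from 1500 nM to 9000 nM.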

Compound 4, half-maximal inhibitory concentration: 7720 nM
The estimate for compound 4 lay 2.2-fold (0.34 log units) below the measured number; the range from low to high includes it.
By their numbers in this assay, from the lowest: compounds 3, 1 and 4 (each within the scatter of the next, the first and the last beyond it); then compound 2.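

Among the compounds shown here, until now, every measured step changed only the group on the sulfonyl sulfur, so this is the first reading in this assay of a change within the shared core. Chloro in place of fluoro, on an aromatic carbon ortho to a hydroxy group, gives a 2.1-fold higher number from compound 3 to compound 4 (0.32 log units; beyond the scatter) and so moves the compound towards weaker inhibition, though the step is modest. This position therefore responds even to an exchange of one halogen for another, with no ring, hydrogen-bond donor, hydrogen-bond acceptor or net charge gained or lost in the swap, but nothing available here accounts for the step.

On these data alone, the step rests on a single pair carrying naphthalen-1-yl on the sulfonyl sulfur, so it remains open whether the same swap would give a similar step with 4-bromophenyl or 4-methylphenyl in that place. Also open, as far as these compounds go, is how this aromatic carbon would respond to a bromo or methyl group, or to plain hydrogen, and whether a methoxy group in place of the hydroxy group would alter the picture.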